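The compounds below may be only part of what the source reports. "The series", "measured", "known", "first", "only" and "open" are said of these compounds alone.

Measured so far in a functional assay, with a stated time of 30 min; a higher number here means a weaker inhibitor, a lower number a stronger inhibitor:
compound 1 `CCCCCCOc1cc(OC)c(Br)cc1C(C)=O` gives 42400000 nM
compound 2 `CCCCCCCCOc1cc(OC)c(Br)cc1C(C)=O` gives 39000000 nM
compound 3 `CCCCCCCCCCCCOc1cc(OC)ccc1C(C)=O` gives 37400000 nM

Compound 2 differs from compound 1 by ethyl in place of hydrogen on a saturated chain carbon, six bonds along the chain from an oxygen on an aromatic ring and the step it made was a 1.1-fold lower number from compound 1 to compound 2 (0.04 log units; within the scatter). Compound 3 carries a different core; how that core differs from the core of compound 1 is not broken down here. The values of compound 3 and compound 2 lie within the scatter of each other, as do those of compound 3 and compound 1, so no order among the three can be read from these numbers.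

Compound 4 `CCCCCCCCCCCCCCOc1cc(OC)ccc1C(C)=O` has not yet been measured. It differs from compound 3 by ethyl in place of hydrogen on a saturated chain carbon, ten or more bonds along the chain from an oxygen on an aromatic ring. This is the same kind of change as from compound 1 to compound 2, though the ethyl enters at a different place along the chain, as the two descriptions of the differences show. Because a 1.1-fold lower number from compound 1 to compound 2 (0.04 log units; within the scatter) stayed within the scatter, the step expected from compound 3 to compound 4 in this assay is a 1.1-fold lower number from compound 3 to compound 4 (0.03 log units; within the scatter), also within the scatter. Compound 4 is therefore estimated at 35000000 nM, expected to fall between 20000000 nM and 65000000 nM.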

Compound 4, half-maximal inhibitory concentration: 43600000 nM
Estimate against measurement, compound 4: 1.2-fold (0.10 log units) below; the range from low to high includes it.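

In this assay, the new step is a 1.2-fold higher number from compound 3 to compound 4 (0.07 log units; within the scatter), so ethyl in place of hydrogen on the chain of the core of compound 3 gives no readable change. These steps do not establish that the chain has no bearing on activity in general, nor do they show a shared effect of the change: each pair shows only that no effect can be read at this chain position and on this core. Across the two cores, the change behaves alike as far as these numbers can tell, with no difference between the two steps that can be read: the same change on two cores in this assay, a 1.1-fold lower number (0.04 log units; within the scatter) from compound 1 to compound 2 and a 1.2-fold higher number (0.07 log units; within the scatter) from compound 3 to compound 4, 1.3-fold (0.10 log units) apart, within the scatter of two such steps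

Still open, as far as these compounds go, is whether a polar group on the chain, such as an amine or a carboxylic acid at its far end, would move the number in this assay beyond the scatter. Also open, from the compounds shown here alone, is whether a longer chain on either core, or a shorter one such as butyl, would do so.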